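The compounds below may be only part of what the source reports. "The series", "measured", "known", "first", "only" and "open" are said of these compounds alone.

Compound 1 `CCCn1c(=O)[nH]c2nc(-c3ccc(S(=O)(=O)N4CCN(c5ccc(F)cc5)CC4)cc3)[nH]c2c1=O` gives > 1000 nM in an assay on CHO cells for displacement of a labelled ligand from adenosine receptor A3 (Homo sapiens), read by scintillation counting, with a stated time of 45 min, in the presence of a further agent that is not named here; a lower number here means a stronger inhibitor, a higher number a weaker inhibitor; this is a limit of the assay, not a number.
Compound 2 `CCCn1c(=O)[nH]c2nc(-c3ccc(S(=O)(=O)N4CCN(c5ccccc5C)CC4)cc3)[nH]c2c1=O` gives > 1000 nM, again a limit.
Compound 3 `CCCn1c(=O)c2[nH]c(-c3ccc(S(=O)(=O)N4CCN(c5ccc(Cl)cc5)CC4)cc3)nc2n(CC)c1=O` gives > 1000 nM, also a limit.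

All three values sit at the same limit (the limit of > 1000 nM in this assay, at which 3 of the 3 values shown sit), so compound 3 stands nowhere on a readable scale; it is known only as a weak binder at that limit, like the other two. Among the compounds with values here, the one measured step, a step that the two limits leave unreadable from compound 1 to compound 2, cannot be read, both of its ends being limits, and it concerns the aryl group on the piperazine nitrogen rather than the position changed here.

Compound 4 `CCCn1c(=O)c2[nH]c(-c3ccc(S(=O)(=O)N4CCN(c5ccc(Cl)cc5)CC4)cc3)nc2n(C)c1=O` differs from compound 3 by hydrogen in place of methyl on a saturated chain carbon bound to an aromatic nitrogen, which read one bond further out is ethyl to methyl. Within the data shown here, no measured step touches this position, and no step in the set is readable at all, so nothing in the data sets a direction or a size for the change. Compound 4 is therefore expected to remain near the limit, estimated at 3000 nM with a range from 800 nM to 15000 nM. The estimated step that the limit leaves unreadable from compound 3 to compound 4 carries no expected direction beyond the scatter, and a further limit rather than a number is the most likely outcome.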

Compound 4, inhibition constant: > 1000 nM
Compound 4 gave a limit, no number (the forecaster's own chance of this, stated with the estimate: 80%); the middle value is on the limit's open side.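

No new step can be read: compound 3 and compound 4 both sit at a limit of the assay, not at a number, so the change between them has no readable size: the limit of > 1000 nM in this assay, at which 4 of the 4 values shown sit.

The compounds shown leave open how strongly any of them binds and what ethyl to methyl does to that binding.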